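Swapping the amide aryl group in a quinoline antiproliferative series

A few compounds are considered here, and "the series" means these few. Any claim that something is new, unique, unknown or untested is made for them only; others in the source may bear on it.

This account follows a single change made to compound 2, whose structure is `CCN1CCN(c2cc(C)c3cc(NC(=O)c4ccc(Cl)cc4)ccc3n2)CC1`. In a functional assay on SK-BR-3 cells (Homo sapiens) for antiproliferative activity, read by MTT assay, with a stated time of 72 h (on this read-out lower numbers stand for stronger inhibition and higher numbers for weaker inhibition), compound 2 gives 3020 nM, the lowest of the three numbers recorded so far. Its nearest neighbour is compound 1, `CCN(CC)CCNc1cc(C)c2cc(NC(=O)c3ccc(Cl)c(Cl)c3)ccc2n1`, which in this assay gives 3710 nM, a value that sits within the scatter of compound 2. The furthest is compound 3, `Cc1cc(N2CCN(C(C)C)CC2)nc2ccc(NC(=O)c3ccc(Cl)c(Cl)c3)cc12`, which in this assay gives 6680 nM, and that gap lies beyond the scatter.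

The new compound is compound 4, `CCN1CCN(c2cc(C)c3cc(NC(=O)c4ccccc4OC)ccc3n2)CC1`. It differs from compound 2 in one place: 2-methoxyphenyl in place of 4-chlorophenyl on a carbonyl carbon.

Within the data shown here, the only measured step that can be checked is a 1.8-fold higher number from compound 1 to compound 3 (0.26 log units; within the scatter), and it concerns the group on the aromatic carbon of the core, not the aryl group on the carbonyl carbon. Among the measured compounds shown here, no measured pair changes the aryl group on the carbonyl carbon alone, so nothing in the data speaks directly to the replacement of 4-chlorophenyl by 2-methoxyphenyl. The three numbers all lie within a narrow band, which gives no ground to expect a large shift in either direction.

Compound 4 is therefore expected to give 3800 nM in this assay, with a range from 1500 nM to 9500 nM. This estimate means a step of a 1.3-fold higher number from compound 2 to compound 4 (0.10 log units; within the scatter), which is expected to stay within the scatter.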

Compound 4, half-maximal inhibitory concentration: 15700 nM
For compound 4 the middle estimate is 4.1-fold (0.62 log units) below the measured one; measured number outside the range, above it.
By their numbers in this assay, from the lowest: compounds 2, 1 and 3 (each within the scatter of the next, the first and the last beyond it); then compound 4.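

In this assay, the aryl group on the carbonyl carbon turns out not to be a neutral place for change: 2-methoxyphenyl in place of 4-chlorophenyl gives a 5.2-fold higher number from compound 2 to compound 4 (0.72 log units; beyond the scatter). Among these compounds, this is the first measured change of this aryl group alone, and it lies beyond the scatter, whereas the one earlier step, which concerned the group on the aromatic carbon of the core, stayed within it. No measurement available here bears on what lies behind this rise.

The single step replaces one substituted phenyl with another, so the compounds shown do not separate the loss of the chlorine from the entry of the methoxy group or from where each group stands on the ring; plain phenyl, 2-chlorophenyl and 4-methoxyphenyl on the same carbonyl carbon would each speak to this. From the compounds shown here alone, it also remains open whether 2-methoxyphenyl would give a similar step on a compound carrying (2-(diethylamino)ethyl)amino or 4-isopropylpiperazin-1-yl on the aromatic carbon of the core, as compound 1 and compound 3 do.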